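Chloro in Place of Hydrogen on Compound 1

A few compounds are considered here, and "the series" means these few. Any claim that something is new, unique, unknown or untested is made for them only; others in the source may bear on it.

Compound 1 `Brc1cccc2c1nnn2CC1CC1` gives 0.6 mL/min/g in an ADME assay on microsomes from liver (Rattus norvegicus, strain Wistar) for metabolic stability, tested at 2.5 uM (a lower number here means slower removal, a higher number faster removal of the compound), the lowest of the three measured numbers, although the gap to compound 3 `CCCn1nnc2c(Br)cccc21`, which gives 0.8 mL/min/g, lies within the scatter, as a 1.3-fold higher number from compound 1 to compound 3 (0.12 log units; within the scatter) shows; compound 2 `CCCCn1nnc2c(Br)cccc21` gives 4.4 mL/min/g, and a 7.3-fold higher number from compound 1 to compound 2 (0.87 log units; beyond the scatter) is beyond it. Compound 4 `Clc1cc(Br)c2nnn(CC3CC3)c2c1` differs from compound 1 by chloro in place of hydrogen on an aromatic carbon. For the measured compounds named here, no measured step touches this place: a 7.3-fold higher number from compound 1 to compound 2 (0.87 log units; beyond the scatter) and a 5.5-fold lower number from compound 2 to compound 3 (0.74 log units; beyond the scatter) both concern the saturated chain carbon bound to an aromatic nitrogen, so they offer no direct guide. Lacking a step of this kind, the expected change for compound 4 is a 1.3-fold higher number from compound 1 to compound 4 (0.12 log units; within the scatter), not beyond the scatter. Compound 4 is therefore estimated at 0.8 mL/min/g, with a range from 0.35 mL/min/g to 1.8 mL/min/g.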

Compound 4, intrinsic clearance in a liver preparation (reported as CLH), per the amount of preparation that the assay uses: 1.1 mL/min/g
Beside the measured number, compound 4's estimate is 1.4-fold (0.14 log units) below it; the range from low to high includes it.
By their numbers in this assay, from the lowest: compounds 1, 3 and 4 (each within the scatter of the next); then compound 2.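

This is the first change shown on the aromatic ring rather than on the chain: at this carbon, para to a fused ring and meta to the bromo group, chloro in place of hydrogen gives a 1.8-fold higher number from compound 1 to compound 4 (0.26 log units; within the scatter) in this assay and so stays within the scatter. On the chain, by contrast, a single change can go beyond it, as with a 5.5-fold lower number from compound 2 to compound 3 (0.74 log units; beyond the scatter) in the same assay. Nothing at hand explains either result. The compounds shown leave open whether fluoro, methoxy or an amine at this carbon would also stay within the scatter. They also leave open whether chloro would do the same on the chains of compound 2 and compound 3.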